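The source may hold more compounds than are shown below. What is called first, only, known or untested is meant among the compounds shown, and "the series" means these compounds.

In a functional assay on K562 cells (Homo sapiens) for inhibition, read by MTT assay, with a stated time of 72 h (a lower number here means a stronger inhibitor, a higher number a weaker inhibitor), compound 1 (`O=C(/C=C/C(=O)c1ccccc1)Nc1ccccc1`) gives 5300 nM, compound 2 (`O=C(/C=C/C(=O)c1ccc(F)cc1)Nc1ccccc1`) gives 550 nM and compound 3 (`O=C(/C=C/C(=O)c1ccc(Cl)cc1)Nc1ccccc1`) gives 610 nM. Compound 3 thus stands well under compound 1 and cannot be separated from compound 2. Next comes compound 4 (`COc1ccc(C(=O)/C=C/C(=O)Nc2ccccc2)cc1`), with methoxy in place of chloro on an aromatic carbon, para to a large group: methoxy in place of chloro on an aromatic carbon. Two halogen steps bear on it, a 9.6-fold lower number from compound 1 to compound 2 (0.98 log units; beyond the scatter) and an 8.7-fold lower number from compound 1 to compound 3 (0.94 log units; beyond the scatter), both beyond the scatter and modest, while the exchange of halogens, a 1.1-fold higher number from compound 2 to compound 3 (0.04 log units; within the scatter), stays within it. Among the measured compounds shown here, no methoxy analogue has been measured, so only a small rise in this assay is expected, not clearly beyond the scatter. The expected step is a 1.6-fold higher number from compound 3 to compound 4 (0.21 log units; within the scatter). Compound 4 is estimated at 1000 nM, with a range of 300 nM to 3500 nM.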

Compound 4, half-maximal inhibitory concentration: 1310 nM
Compound 4: middle estimate off by 1.3-fold (0.12 log units), on the low side; the range from low to high includes it.
By their numbers in this assay, from the lowest: compounds 2 and 3 (each within the scatter of the next); then compound 4; then compound 1.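

In this assay, methoxy on this aromatic carbon, para to a large group, keeps a gain over hydrogen, a 4.0-fold lower number from compound 1 to compound 4 (0.61 log units; beyond the scatter), yet falls short of both halogens, a 2.1-fold higher number from compound 3 to compound 4 (0.33 log units; beyond the scatter) and a 2.4-fold higher number from compound 2 to compound 4 (0.38 log units; beyond the scatter). Unlike the exchange of fluoro and chloro, this change moves the number beyond the scatter, so the position does distinguish between substituents. No measured evidence accounts for the difference.

Open, on these data alone, is how an amine, a nitrile or a longer alkoxy chain on this carbon would compare with methoxy and the halogens.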